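A few compounds are considered here, and "the series" means these few. Any claim that something is new, unique, unknown or untested is made for them only; others in the source may bear on it.

Compound 1 `O=C(Nc1ccc(Cl)cc1)Nc1cccc(CNc2nccnc2Cl)c1` is one of three close analogues that share a common core and differ only in the aromatic group carried on an amide-type nitrogen of the urea. In a functional assay on MGC-803 cells (Homo sapiens) for antiproliferative activity, read by MTT assay, with a stated time of 48 h (a higher number here means a weaker inhibitor, a lower number a stronger inhibitor), compound 1 gives 4980 nM, which is the lowest of the three numbers and so marks compound 1 as the strongest inhibitor of the set. Compound 2 `CN(C)c1ccc(NC(=O)Nc2cccc(CNc3nccnc3Cl)c2)cc1` gives 11500 nM, and compound 3 `Cc1cccc(NC(=O)Nc2cccc(CNc3nccnc3Cl)c2)c1` gives 14600 nM. The step of a 2.3-fold higher number from compound 1 to compound 2 (0.36 log units; beyond the scatter) and the step of a 2.9-fold higher number from compound 1 to compound 3 (0.47 log units; beyond the scatter) both run in the same direction, toward weaker inhibition, when the 4-chlorophenyl of compound 1 is exchanged, while the step of a 1.3-fold higher number from compound 2 to compound 3 (0.10 log units; within the scatter) shows that the two replacements land close together.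

Compound 4 `CCc1ccccc1NC(=O)Nc1cccc(CNc2nccnc2Cl)c1` has not yet been measured in this assay. Its difference from compound 1 is 2-ethylphenyl in place of 4-chlorophenyl on an amide-type nitrogen. The two measured steps that bear on it, from compound 1 to compound 2 and from compound 1 to compound 3, each exchanged the same 4-chlorophenyl for another aromatic group and each gave a modest loss. A modest weakening is therefore expected, described by the step of a 2.4-fold higher number from compound 1 to compound 4 (0.38 log units; beyond the scatter). For compound 4 the estimated value is 12000 nM, with a range from 5000 nM to 30000 nM.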

Compound 4, half-maximal inhibitory concentration: 9370 nM
For compound 4 the middle estimate is 1.3-fold (0.11 log units) above the measured one, and the stated range covers the measured number.
By their numbers in this assay, from the lowest: compounds 1, 4, 2 and 3 (each within the scatter of the next, the first and the last beyond it).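

Replacing 4-chlorophenyl with 2-ethylphenyl on the amide-type nitrogen gives a 1.9-fold higher number from compound 1 to compound 4 (0.27 log units; within the scatter), so compound 4 cannot be told apart from compound 1, and this exchange is the one exception among the three replacements of 4-chlorophenyl, since the steps to compound 2 and compound 3 lie beyond the scatter. Compound 4 also cannot be separated from the other two analogues, with a 1.6-fold lower number from compound 3 to compound 4 (0.19 log units; within the scatter) and a 1.2-fold lower number from compound 2 to compound 4 (0.09 log units; within the scatter), so it sits within the scatter of all three earlier compounds, and the chlorine of compound 1 can be absent from this aromatic group without a clear loss in this one case. Nothing available explains why this carbon-only group behaves this way, so the result stands as an observation without a cause.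

The compounds shown do not separate the effect of the group itself from the effect of where it sits on the ring, as the ethyl and chloro groups each appear at only one place. They also leave open what a plain phenyl ring, a longer chain such as butyl, or a ring bearing a carboxylic acid or an amine would do at this nitrogen.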